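The compounds below may be only part of what the source reports. "The series", "measured", "known", "first", "only" and "open" are said of these compounds alone.

Measured so far:
- compound 1 `CN(C)CCn1cnnc1-c1cc(Oc2ccc(NC(=O)N/N=C/c3cc(C(C)(C)C)cc(C(C)(C)C)c3O)cc2F)ccn1`: 680 nM
- compound 2 `COc1ccc(/C=N/NC(=O)Nc2ccc(Oc3ccnc(-c4nncn4CCN(C)C)c3)c(F)c2)c(OC)c1OC`: 3970 nM
- compound 3 `CN(C)CCn1cnnc1-c1cc(Oc2ccc(NC(=O)N/N=C/c3ccc(F)cc3)cc2F)ccn1`: 1370 nM

In a functional assay on HT-29 cells (Homo sapiens) for cytotoxicity, read by MTT assay, with a stated time of 72 h (on this read-out lower numbers stand for stronger inhibition and higher numbers for weaker inhibition), compound 3 holds the second highest of the three numbers. Compound 1 is its nearest neighbour and sits within the scatter, so no order between compound 1 and compound 3 is claimed. For the measured compounds named here, compound 2 is the furthest: the only single-site step, a 2.9-fold lower number from compound 2 to compound 3 (0.46 log units; beyond the scatter), separates them.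

Compound 4 `CN(C)CCn1cnnc1-c1cc(Oc2ccc(NC(=O)N/N=C/c3ccc(Cl)cc3)cc2F)ccn1` differs from compound 3 by chloro in place of fluoro on an aromatic carbon. Going by the values given here, no measured step covers a halogen swap at this position; the step from compound 2 to compound 3 replaced a whole trimethoxyphenyl and bears on it only loosely. The expected step is therefore a 1.2-fold lower number from compound 3 to compound 4 (0.10 log units; within the scatter), essentially none beyond the scatter. Compound 4 is estimated at 1100 nM, with a range from 450 nM to 2700 nM.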

Compound 4, half-maximal inhibitory concentration: 530 nM
The estimate for compound 4 lay 2.1-fold (0.32 log units) above the measured number; the measured number falls inside the stated range.
By their numbers in this assay, from the lowest: compounds 4, 1 and 3 (each within the scatter of the next, the first and the last beyond it); then compound 2.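

In this assay this position distinguishes between two halogens: 4-chlorophenyl in place of 4-fluorophenyl gives a 2.6-fold lower number from compound 3 to compound 4 (0.41 log units; beyond the scatter), a change of a single atom that lies beyond the scatter. Set against the 2,3,4-trimethoxyphenyl group, the 4-chlorophenyl group gives a larger step, a 7.5-fold lower number from compound 2 to compound 4 (0.87 log units; beyond the scatter), than the 4-fluorophenyl group did. The compounds shown leave open how bromo, methyl or nitrile at this place would compare with chloro, and whether the halogen step carries over to other assays. No available evidence accounts for the chloro result.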